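The compounds below may be only part of what the source reports. "The series", "measured", "known", "first", "only" and "open" are said of these compounds alone.

Working notes on the thiosemicarbazone series.

Of the compounds shown here, three have been measured in a functional assay on T98G cells (Homo sapiens) for cytotoxicity, read by MTT assay, with a stated time of 48 h; on this read-out lower numbers stand for stronger inhibition and higher numbers for weaker inhibition. Compound 1 `C/C(=N/NC(=S)Nc1ccccc1I)c1ccccn1` gives 8.09 nM. Compound 2 `C/C(=N/NC(=S)Nc1ccc(Cl)cc1)c1ccccn1` gives 5.9 nM, the lowest of the three numbers; the gap to compound 1 is within the usual scatter, so no order between compound 1 and compound 2 is claimed. Compound 3 `CC(=NNC(=S)Nc1cccc(I)c1)c1ccccn1` gives 61 nM, which lies beyond the scatter from compound 2 and from compound 1.

Compound 4 `CC(=NNC(=S)Nc1ccc(Cl)cc1)c1ccccn1` is the next entry. Against compound 2 the difference is only in how the structure is drawn: the two compounds have the same atoms and bonds; at least one stereo element is drawn with a configuration in one of them and without one in the other: 1 of 1 stereo elements differ; a double bond is drawn Z in compound 2 and without a configuration in compound 4. No atoms leave and none enter, so the two entries describe the same connectivity and the same substituents.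

Among the compounds with values here, no step between measured compounds is available for a change of this kind. Given identical atoms and bonds, the expected step is none beyond the scatter in either direction; the estimated step is a 1.0-fold higher number from compound 2 to compound 4 (0.01 log units; within the scatter). Compound 4 is therefore expected to give about 6 nM, with a range from 3 nM to 12 nM.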

Compound 4, half-maximal inhibitory concentration: 5.9 nM
For compound 4 the middle estimate is 1.0-fold (0.01 log units) above the measured one, within the range that was stated.
By their numbers in this assay, from the lowest: compounds 2, 4 and 1 (each within the scatter of the next); then compound 3.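

Within the data shown here, the pair adds one point that the earlier compounds could not: in this assay, removing the drawn configuration from the double bond leaves the reading unmoved, with no change at the digits printed from compound 2 to compound 4 (within the scatter). Compound 2 and compound 4 can therefore be treated as one data point for reading the series, not as independent evidence for a substituent effect. The step says nothing about a preference for one double-bond geometry, since the only thing separating the entries is a matter of drawing: the fact that one of compounds 2 and 4 is drawn with a defined configuration and the other without, at the place where they differ

Still open, on these data alone, is how a compound explicitly drawn with the opposite double-bond geometry would read. Also open, as far as these compounds go, is whether a methoxy group, an amine or a carboxylic acid in place of the chlorine of compound 2 would hold the number.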